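The source may report more compounds than this note shows. Statements on the series, on what has been measured and on what is new or still open speak of the compounds shown alone.

Compound 2 `CCN(CC)CCNc1nc(-c2ccc(NC(=O)Nc3ccc(Cl)cc3)cc2)nc2c(Cl)c(Cl)sc12`: 430 nM
Compound 1 `CN(C)CCNc1nc(-c2ccc(NC(=O)Nc3ccc(Cl)cc3Cl)cc2)nc2c(Cl)c(Cl)sc12`: 1280 nM

Both numbers come from a functional assay on HT-29 cells (Homo sapiens) for cytotoxicity, read by MTT assay, with a stated time of 72 h; on this read-out higher numbers stand for weaker inhibition and lower numbers for stronger inhibition. Compound 2 stands at the lowest of the two numbers in this assay; its nearest neighbour is compound 1, whose number lies higher by a margin beyond the scatter of this assay. Among the compounds with values here, no single-change step links these two, since compound 1 and compound 2 differ in more than one place, so their values are simply noted side by side.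

Compound 3 `CCN(CC)CCNc1nc(-c2ccc(NC(=O)Nc3ccc(Cl)cc3Cl)cc2)nc2c(Cl)c(Cl)sc12` has not yet been measured. It differs from compound 2 by chloro in place of hydrogen on an aromatic carbon, a chloro in place of hydrogen on an aromatic carbon, and shares its 2,4-dichlorophenyl group with compound 1 while the rest of its structure matches compound 2. Within the data shown here, with no single-change step to lean on, the step of a 1.7-fold higher number from compound 2 to compound 3 (0.24 log units; within the scatter) is expected to be modest and upward, toward weaker inhibition, roughly at the edge of the scatter. Compound 3 is therefore estimated at about 750 nM in this assay, within a range from 250 nM to 2200 nM.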

Compound 3, half-maximal inhibitory concentration: 1140 nM
Beside the measured number, compound 3's estimate is 1.5-fold (0.18 log units) below it, within the range that was stated.
By their numbers in this assay, from the lowest: compound 2; then compounds 3 and 1 (each within the scatter of the next).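

In this assay, within the data shown here, chloro in place of hydrogen, ortho to a large group, turns the 4-chlorophenyl into the 2,4-dichlorophenyl group and gives a 2.7-fold higher number from compound 2 to compound 3 (0.42 log units; beyond the scatter), the first single-change reading at this position, toward weaker inhibition. With the 2,4-dichlorophenyl group in place, diethylamino in place of dimethylamino gives a 1.1-fold lower number from compound 1 to compound 3 (0.05 log units; within the scatter), so of the two single changes only the chloro step lies beyond the scatter. No measurement available here bears on why the chloro step moves the number.

From the compounds shown here alone, whether a smaller fluoro or a methoxy group at this same place would give a similar step remains open. So does the response to a cyclic amine such as morpholine in place of the diethylamino group, and whether the chloro step would be the same with dimethylamino on the chain.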